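This account rests on a few compounds, and the source may have more. Where it says the series, first, only, none or still open, it means among the compounds named here.

Working notes on the series. Compound 1 `ClCc1ccc(Cn2cnc3c(Cl)ncnc32)cc1`, compound 2 `ClCc1cccc(Cn2cnc3ncnc(Cl)c32)c1` and compound 3 `ClCc1ccc(Cn2cnc3c(Cl)nc(Cl)nc32)cc1` have been tested in a functional assay on UACC-257 cells (Homo sapiens) for cytotoxicity, read by sulforhodamine B assay, with a stated time of 48 h; a higher number here means a weaker inhibitor of growth, a lower number a stronger inhibitor of growth. Compound 1 gives 28800 nM in this assay, compound 3 gives 33100 nM, and compound 2 gives 5490 nM. Compound 2 stands lowest of the three; its nearest neighbour is compound 1, and both gaps, to compound 1 and to compound 3, lie beyond the scatter, so compound 2 is the strongest inhibitor of growth so far. Compound 1 and compound 2 are built from the same atoms joined differently; the difference between the two cores is not broken down here.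

Compound 3 is obtained from compound 1 by one change, (chloro in place of hydrogen on an aromatic carbon). In this assay that change made a 1.1-fold higher number from compound 1 to compound 3 (0.06 log units; within the scatter).

Compound 4 `ClCc1cccc(Cn2cnc3nc(Cl)nc(Cl)c32)c1` has not yet been tested. Going by the values given here, it is obtained from compound 2 by chloro in place of hydrogen on an aromatic carbon, which is the same change as the one from compound 1 to compound 3, at a place described in the same words. Since the measured step from compound 1 to compound 3 stayed within the scatter, the step from compound 2 to compound 4 is expected to be small as well, estimated as a 1.1-fold higher number from compound 2 to compound 4 (0.04 log units; within the scatter). For compound 4 in this assay the expected value is therefore 6000 nM, with a plausible range from 3000 nM to 12000 nM. This rests on a single measured precedent, so the range is kept wide.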

Compound 4, concentration for total growth inhibition: 15100 nM
Estimate against measurement, compound 4: 2.5-fold (0.40 log units) below, and the stated range ends below it.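

In this assay chloro in place of hydrogen on an aromatic carbon makes a 2.8-fold higher number from compound 2 to compound 4 (0.44 log units; beyond the scatter) on the core of compound 2, whereas the same change on the core of compound 1 stayed within the scatter. Read singly, the two steps fall on different sides of the scatter, but set side by side they do not differ by more than two such steps can vary, so the series gives no measured sign that the outcome of this change depends on the core: the same change on two cores in this assay, a 1.1-fold higher number (0.06 log units; within the scatter) from compound 1 to compound 3 and a 2.8-fold higher number (0.44 log units; beyond the scatter) from compound 2 to compound 4, 2.4-fold (0.38 log units) apart, within the scatter of two such steps. This does not show that the change behaves alike on both cores, for it rests on one pair per core, and a real difference of the size seen between the two steps could not be told from scatter with these compounds.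

The compounds shown leave open whether any other group placed between two ring nitrogen atoms, such as an amine, a methoxy group or a nitrile, would move the number further than chloro does. Going by these compounds alone, they also leave open whether the step seen here would carry to a third core, as only two cores bear this change so far.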